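A few compounds are considered here, and "the series" means these few. Any claim that something is new, unique, unknown or untested is made for them only; others in the source may bear on it.

Measured so far: compound 1 `COc1ccc(C(=O)Nc2cccc(-c3oc4cc(-c5ccc(F)cc5)ccc4c(=O)c3O)c2)cc1` gives 8420 nM; compound 2 `O=C(Nc1cccc(-c2oc3cc(-c4ccc(F)cc4)ccc3c(=O)c2O)c1)c1ccc(F)cc1F` gives 26400 nM; compound 3 `COc1cccc(C(=O)Nc2cccc(-c3oc4cc(-c5ccc(F)cc5)ccc4c(=O)c3O)c2)c1` gives 9950 nM, all in a functional assay on HepG2 cells (Homo sapiens) for antiproliferative activity, read by CCK-8 assay, with a stated time of 72 h; a higher number here means a weaker inhibitor, a lower number a stronger inhibitor.

Compound 3 stands second highest of the three numbers: its nearest neighbour is compound 1, within the scatter, and its furthest is compound 2. Compound 4 `O=C(Nc1cccc(-c2oc3cc(-c4ccc(F)cc4)ccc3c(=O)c2O)c1)c1ccc(Br)cc1F` differs from compound 3 in one place: 4-bromo-2-fluorophenyl in place of 3-methoxyphenyl on a carbonyl carbon. The step that bears on this is a 2.7-fold lower number from compound 2 to compound 3 (0.42 log units; beyond the scatter), where a halogenated phenyl on the carbonyl carbon gave the higher number; compound 4 again carries a halogenated phenyl there, and a 3.1-fold higher number from compound 1 to compound 2 (0.50 log units; beyond the scatter) points the same way. Compound 4 is therefore expected to give a higher number than compound 3, as a 2.0-fold higher number from compound 3 to compound 4 (0.30 log units; within the scatter). Compound 4 is estimated at 20000 nM, with a range from 8000 nM to 50000 nM.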

Compound 4, half-maximal inhibitory concentration: > 100000 nM
Compound 4 gave a limit, no number; the forecaster's own chance of this, stated with the estimate: 10%; middle value at least 5.0-fold (0.69 log units) away from the limit.
By their numbers in this assay, from the lowest: compounds 1 and 3 (each within the scatter of the next); then compound 2. At a limit, above all of these: compound 4.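

In this assay compound 4 gives a limit and not a number: the limit of > 100000 nM in this assay, at which 1 of the 4 values shown sits. Bromo in place of fluoro on an aromatic carbon is enough to matter at this position, with an at least 3.7-fold higher number from compound 2 to compound 4 (0.57 log units; beyond the scatter), so the two halogenated phenyls on the carbonyl carbon do not read alike. For the compounds shown here, the methoxyphenyl compounds lie further off, with an at least 10-fold higher number from compound 3 to compound 4 (1.00 log units; beyond the scatter) and an at least 11-fold higher number from compound 1 to compound 4 (1.07 log units; beyond the scatter), and these gaps are wider than any step among the earlier compounds.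

As far as these compounds go, the true size of these steps stays open. So does whether a 4-chloro-2-fluorophenyl or a 4-bromophenyl on the carbonyl carbon would fall with compound 2 or with compound 4.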